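Swapping a thiophene for a phenyl on the ketone

The source may hold more compounds than are shown below. What is called first, only, known or untested is meant among the compounds shown, and "the series" means these compounds.

Among the compounds with values here, in a functional assay on HCT-116 cells (Homo sapiens) for inhibition, read by sulforhodamine B assay, with a stated time of 72 h (a higher number here means a weaker inhibitor, a lower number a stronger inhibitor), compound 2 `O=C(/C=C/c1cn(-c2ccccc2)nc1-c1cccnc1)c1ccsc1` gives 1300 nM, the lowest of the two numbers measured so far, while compound 1 `COc1ccc(C(=O)/C=C/c2cn(-c3ccccc3)nc2-c2ccsc2)c(OC)c1` gives 2200 nM; the two values lie within the usual scatter of one another. Compound 3 `O=C(/C=C/c1cn(-c2ccccc2)nc1-c1cccnc1)c1ccccc1` differs from compound 2 in one place: phenyl in place of thiophen-3-yl on a carbonyl carbon. Within the data shown here, no measured pair shows this change, so no step beyond the scatter is expected in either direction. Compound 3 is therefore estimated at 1300 nM in this assay, within a range of 500 nM to 3500 nM. This estimate means a step of no change at the digits printed from compound 2 to compound 3 (within the scatter), expected to stay within the scatter.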

Compound 3, half-maximal inhibitory concentration: 2000 nM
Compound 3: the middle estimate sits 1.5-fold (0.19 log units) below what was measured, and the stated range covers the measured number.
By their numbers in this assay, from the lowest: compounds 2, 3 and 1 (each within the scatter of the next).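

Putting phenyl in place of thiophen-3-yl on the carbonyl carbon gives a 1.5-fold higher number from compound 2 to compound 3 (0.19 log units; within the scatter) in this assay. Within the data shown here, this is the first direct reading of this position: a five-membered aromatic ring with a sulfur atom and a six-membered ring of carbon only cannot be told apart here. No measurement on hand offers a reason for this. Still open, as far as these compounds go, is whether this carbonyl carbon needs an aromatic ring at all, since a simple methyl group or an amine in the same place would test that.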